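Carbamate series: cyclohexyl replacing hexyl on the nitrogen

The source may report more compounds than this note shows. Statements on the series, on what has been measured and on what is new or still open speak of the compounds shown alone.

Working notes on the carbamate pair. Compound 1 `O=C(NC1CCCCC1)Oc1ccc(C2=NCCS2)cc1` in an assay on cell membranes (strain Wistar) for inhibition of Monoglyceride lipase (Rattus norvegicus), read by HPLC (on this read-out lower numbers stand for stronger inhibition and higher numbers for weaker inhibition), gives 27000 nM. Compound 2 `CCCCCCNC(=O)Oc1ccc(C(=O)OC)cc1` in this assay gives 35000 nM, the highest of the two numbers obtained so far; its nearest neighbour is compound 1, and the two values lie within the scatter of each other, so no order between them can be read. Compound 3 `COC(=O)c1ccc(OC(=O)NC2CCCCC2)cc1` is not yet measured in this assay. It differs from compound 2 by cyclohexyl in place of hexyl on an amide-type nitrogen. Among the compounds with values here, no measured pair isolates this change, so no step between measured compounds can be quoted for it. Within the data shown here, both compounds measured so far show only weak inhibition. In this assay the expected step is a 1.4-fold lower number from compound 2 to compound 3 (0.15 log units; within the scatter), a move that stays within the scatter. Compound 3 is accordingly estimated at 25000 nM in this assay, with a range from 8000 nM to 80000 nM.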

Compound 3, half-maximal inhibitory concentration: 14000 nM
Compound 3: middle estimate off by 1.8-fold (0.25 log units), on the high side; low and high end bracket the measured number.
By their numbers in this assay, from the lowest: compounds 3, 1 and 2 (each within the scatter of the next, the first and the last beyond it).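

In this assay the group on the amide-type nitrogen now has a measured step: cyclohexyl in place of hexyl gives a 2.5-fold lower number from compound 2 to compound 3 (0.40 log units; beyond the scatter), a modest change and the first in the series to stand beyond the scatter. With cyclohexyl held on the nitrogen, exchanging the group on the aromatic carbon gives a 1.9-fold lower number from compound 1 to compound 3 (0.29 log units; within the scatter), so no order can be read for that exchange. Nothing at hand accounts for the cyclohexyl step.

From the compounds shown here alone, whether the step depends on the ring or on the six carbons in another arrangement stays open, and a cyclopentyl, phenyl or benzyl group on the nitrogen would bear on this. Also open, going by these compounds, is whether the cyclohexyl for hexyl step holds on the core of compound 1.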